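Furan-2-yl to 2,4-Difluorophenyl on a Saturated Ring Carbon

The compounds below may be only part of what the source reports. "The series", "measured", "known", "first", "only" and "open" are said of these compounds alone.

Of the compounds shown here, three of this set have been measured in an assay on cells for inhibition of histone deacetylase 8 (Homo sapiens), read by fluorescence, with a stated time of 30 min; on this read-out lower numbers stand for stronger inhibition and higher numbers for weaker inhibition. Compound 1 `O=C1NC(=O)/C(=C\c2ccc(OCC(=O)N3N=C(c4ccccc4)CC3c3ccccc3)cc2)S1` gives 20000 nM. Within the data shown here, compound 2 `Cc1ccc(C2CC(c3ccccc3)=NN2C(=O)COc2ccc(/C=C3/SC(=O)NC3=O)cc2)cc1` gives 31000 nM, and the single change between them, a 1.6-fold higher number from compound 1 to compound 2 (0.19 log units; within the scatter), leaves the two values within the usual scatter of each other. Compound 3 `O=C1NC(=O)/C(=C\c2ccc(OCC(=O)N3N=C(c4ccc(F)cc4)CC3c3ccco3)cc2)S1` is reported only as a limit of the assay, > 50000 nM, so no number is known for it; it sits at the limit of > 50000 nM in this assay, at which 1 of the 3 values shown sits, and among the values shown it is the one not resolved into a number.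

Compound 4 `O=C1NC(=O)/C(=C\c2ccc(OCC(=O)N3N=C(c4ccc(F)cc4)CC3c3ccc(F)cc3F)cc2)S1` differs from compound 3 in one place: 2,4-difluorophenyl in place of furan-2-yl on a saturated ring carbon. Among the measured compounds shown here, compound 3 differs from compound 1 and compound 2 in more than one place, so no single measured step bears on this change; the only step on record, the methyl for hydrogen exchange between compound 1 and compound 2, concerns a different part of the molecule and lies within the scatter. Because compound 3 is a limit, the step of an at least 1.4-fold lower number from compound 3 to compound 4 (0.15 log units; that floor lies within the scatter) is an estimate from weak footing. Compound 4 is expected to give about 35000 nM, with a range from 12000 nM to 100000 nM, and it may again be reported only as a limit.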

Compound 4, half-maximal inhibitory concentration: > 50000 nM
Compound 4 gave a limit, no number; the forecaster's own chance of this, stated with the estimate: 45%; middle value at least 1.4-fold (0.15 log units) away from the limit.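

Compound 3 and compound 4 are both reported only as limits in this assay, so the step between them cannot be read: the limit of > 50000 nM in this assay, at which 2 of the 4 values shown sit.

The compounds shown leave open how 2,4-difluorophenyl and furan-2-yl on this saturated ring carbon compare, and what number either compound would give.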